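The source may hold more compounds than are shown below. What is called first, only, known or untested is meant among the compounds shown, and "the series" means these compounds.

Compound 1 `CN(C)c1nc2cc(Cl)c(Cl)cc2n1COCCO` gives > 100000 nM in a functional assay on KB cells (Homo sapiens) for inhibition (a lower number here means a stronger inhibitor, a higher number a weaker inhibitor), which is a limit of the assay. Compound 2 `Nc1nc2c(Cl)cc(Cl)cc2n1COCCO` gives > 100000 nM in this assay, again a limit. Compound 3 `OCCOCn1c(S)nc2c(Cl)cc(Cl)cc21` gives > 100000 nM in this assay, also a limit.

Compound 1 therefore stands nowhere in particular on the numbers shown: it has only a limit, and the two further values shown are limits as well (the limit of > 100000 nM in this assay, at which 3 of the 3 values shown sit). Among the measured compounds shown here, the only step between measured compounds that differ in one place, from compound 2 to compound 3, is a step that the two limits leave unreadable from compound 2 to compound 3, and it tells nothing about size or direction.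

Compound 4 `OCCOCn1c(Br)nc2cc(Cl)c(Cl)cc21` differs from compound 1 by bromo in place of dimethylamino on an aromatic carbon. For the measured compounds named here, no measured step bears on this change, and the one step that is known is unreadable, so nothing in the data points to a step in either direction beyond the scatter in this assay. Since all three measured compounds sit at the limit, the most likely outcome for compound 4 is expected to be another limit. The step from compound 1 to compound 4 is expected to be a number no higher from compound 1 to compound 4 (the limit leaves the size open). For compound 4 the estimate in this assay is 100000 nM, with a range from 30000 nM to 300000 nM.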

Compound 4, half-maximal inhibitory concentration: > 100000 nM
Compound 4 was reported as a limit; the forecaster's own chance of this, stated with the estimate: 80%; the middle value lies on the limit itself.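

In this assay compound 4 is reported only as a limit, as is compound 1, so no step can be read for bromo in place of dimethylamino, in either size or direction: the limit of > 100000 nM in this assay, at which 4 of the 4 values shown sit. The compounds shown leave open whether any change to the shared core would give a measurable inhibition in this assay, and how large it would be.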